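A few compounds are considered here, and "the series" means these few. Any claim that something is new, unique, unknown or untested is made for them only; others in the source may bear on it.

Measured compounds in a functional assay on DU-145 cells (Homo sapiens) for inhibition, read by trypan blue exclusion, with a stated time of 72 h; on this read-out higher numbers stand for weaker inhibition and lower numbers for stronger inhibition:
- compound 1 `Cn1c(=O)c(S(=O)(=O)c2ccc(C(=O)O)cc2)cc2cnc(Nc3ccc4[nH]ccc4c3)nc21`: 10000 nM
- compound 2 `Cn1c(=O)c(S(=O)(=O)c2ccc(F)cc2F)cc2cnc(Nc3ccncn3)nc21`: 50000 nM

Compound 1 carries the lower of the two numbers in this assay. Compound 2 differs from it in more than one place and gives a number well beyond the scatter above that of compound 1, so compound 1 is the stronger inhibitor of the pair; what the several changes contribute individually cannot be separated from these two points alone.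

Compound 3 `Cn1c(=O)c(S(=O)(=O)c2ccc(Br)cc2)cc2cnc(Nc3ccc4[nH]ccc4c3)nc21` has not yet been measured. It differs from compound 1 in one place only: bromo in place of carboxy on an aromatic carbon. For the measured compounds named here, no pair of measured compounds shows the effect of this change, and compound 2 shares neither the aryl amine nor the sulfone substituent of compound 3, so it offers no guide to the step.

In the absence of any comparable step the size is uncertain, and the expected step from compound 1 to compound 3 is a 1.7-fold lower number from compound 1 to compound 3 (0.22 log units; within the scatter), treated as possibly no change beyond the scatter. Compound 3 is estimated at 6000 nM in this assay, with a range from 1500 nM to 25000 nM.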

Compound 3, half-maximal inhibitory concentration: 5000 nM
Beside the measured number, compound 3's estimate is 1.2-fold (0.08 log units) above it; low and high end bracket the measured number.
By their numbers in this assay, from the lowest: compounds 3 and 1 (each within the scatter of the next); then compound 2.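

In this assay, the position on the aryl sulfone now has its first direct comparison: exchanging 4-carboxyphenyl for 4-bromophenyl gives a 2.0-fold lower number from compound 1 to compound 3 (0.30 log units; within the scatter) with the rest of the molecule unchanged. The read-out therefore does not separate the two groups at this position, even though carboxy brings a hydrogen-bond donor and a hydrogen-bond acceptor and bromo brings neither, so neither that donor and acceptor pair nor the three heavy atoms of carboxy are shown to matter to the number in this single comparison. No measurement available here accounts for this result.

Still open, on these data alone, is whether any group at this position moves the number beyond the scatter, for example an amine, a methoxy group, a chloro group or a plain hydrogen. For the compounds shown here, also open is whether carboxy and bromo would stay this close with the aryl amine of compound 2 on the shared core, as the one step available was read only with the aryl amine of compound 1 and compound 3.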